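Isobutyl for Isopropyl: Three Compounds at the Assay Limit

The source may hold more compounds than are shown below. What is called first, only, known or untested is meant among the compounds shown, and "the series" means these compounds.

Measured compounds:
In a functional assay on MRC5 cells (Homo sapiens) for inhibition, read by microscopy and resazurin assay, with a stated time of 72 h (a lower number here means a stronger inhibitor, a higher number a weaker inhibitor), compound 1 `COC(=O)[C@H](CC(C)C)NC(=O)c1cccc(/C=C2\SC(=O)N(CC(=O)NOCc3ccccc3)C2=O)c1` gives > 128000 nM, which is a limit of the assay.
In this assay compound 2 `COC(=O)[C@@H](NC(=O)c1cccc(/C=C2\SC(=O)N(CC(=O)NOCc3ccccc3)C2=O)c1)C(C)C` gives > 128000 nM, also a limit.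
In this assay compound 3 `CC(C)[C@H](NC(=O)[C@H](C)NC(=O)c1cn(CC(=O)NOCc2ccccc2)c2ccccc12)C(=O)O` gives > 128000 nM, again a limit.

Compound 2 and compound 1 share a core and differ by isobutyl in place of isopropyl on a saturated chain carbon bound to an amide-type nitrogen and a carbonyl carbon. The step that the two limits leave unreadable from compound 2 to compound 1 cannot be sized, as both values are limits. The difference between the core of compound 3 and the core of compound 2 is not broken down here. Compound 4 `CC(C)C[C@H](NC(=O)[C@H](C)NC(=O)c1cn(CC(=O)NOCc2ccccc2)c2ccccc12)C(=O)O` has not yet been measured and differs from compound 3 by isobutyl in place of isopropyl on a saturated chain carbon bound to an amide-type nitrogen and a carbonyl carbon, the same kind of change as from compound 2 to compound 1. Because the limit of > 128000 nM in this assay, at which 3 of the 3 values shown sit, holds for every compound shown, the expected step that the limit leaves unreadable from compound 3 to compound 4 from compound 3 to compound 4 is negligible. Compound 4 is therefore expected to give about 200000 nM in this assay, estimated to lie between 60000 nM and 600000 nM.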

Compound 4, half-maximal inhibitory concentration: > 128000 nM
Compound 4: only a limit was reported; the forecaster's own chance of this, stated with the estimate: 90%; the middle value is on the limit's open side.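

In this assay, for the compounds shown here, compound 3 and compound 4 both sit at a limit of the assay, so no step between them can be read. The compounds shown leave open whether isobutyl in place of isopropyl changes inhibition at all.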